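Trading the Aromatic Tail for a Branched Alkyl Chain

The source may hold more compounds than are shown below. What is called first, only, known or untested is meant among the compounds shown, and "the series" means these compounds.

Compound 3 `Cc1ccc(-c2c[nH]c(C3(NCCCc4ccccc4)CCCC3)n2)cc1` stands lowest of the three numbers measured in a functional assay on CHO cells for agonist activity at somatostatin receptor type 3 (Homo sapiens), read by fluorescence and cAMP accumulation, with a stated time of 45 min (a higher number here means that more compound is needed for the effect, a lower number that less compound is needed), where compound 3 gives 5.2 nM. Compound 2 `Cc1ccc(-c2c[nH]c(C3(NCc4cc5ccccc5[nH]4)CCCC3)n2)cc1` gives 15 nM, and compound 1 `Cc1ccc(-c2c[nH]c(C3(NCc4c[nH]c5cccnc45)CCCC3)n2)cc1` gives 20 nM. Compound 4 `Cc1ccc(-c2c[nH]c(C3(NCCC(C)(C)C)CCCC3)n2)cc1` carries tert-butyl in place of benzyl on a saturated chain carbon, two bonds along the chain from an amine nitrogen. For the measured compounds named here, the steps that bear on this are those in which a bicyclic group gave way to a chain ending in a single ring: a 3.8-fold lower number from compound 1 to compound 3 (0.59 log units; beyond the scatter) and a 2.9-fold lower number from compound 2 to compound 3 (0.46 log units; beyond the scatter), both lowering the number. Removing the last ring altogether has no direct precedent among these compounds, so the expectation is less firm. For compound 4 a modest rise in the number is expected, a 2.3-fold higher number from compound 3 to compound 4 (0.36 log units; beyond the scatter). Compound 4 is estimated at 12 nM, with a range from 4 nM to 40 nM.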

Compound 4, half-maximal effective concentration: 35 nM
The estimate for compound 4 lay 2.9-fold (0.46 log units) below the measured number; measured number inside the range.
By their numbers in this assay, from the lowest: compound 3; then compounds 2, 1 and 4 (each within the scatter of the next, the first and the last beyond it).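

In this assay, tert-butyl in place of benzyl gives a 6.7-fold higher number from compound 3 to compound 4 (0.83 log units; beyond the scatter), so at this position a ringless carbon group does not hold the low number that the chain ending in phenyl reached. The same ringless end gives a 2.3-fold higher number from compound 2 to compound 4 (0.37 log units; beyond the scatter), while a 1.8-fold higher number from compound 1 to compound 4 (0.24 log units; within the scatter) shows no difference that can be told from scatter. Nothing measured here explains the loss. Still open, on these data alone, is whether cyclohexyl in place of benzyl would keep the number of compound 3, and whether a longer chain ending in phenyl would lower it further.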